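The source may report more compounds than this note shows. Statements on the series, on what has been measured and on what is new or still open speak of the compounds shown alone.

Measured in a functional assay on SW480 cells (Homo sapiens) for antiproliferative activity, read by MTT assay, with a stated time of 48 h; a lower number here means a stronger inhibitor, a higher number a weaker inhibitor:
- Compound 1 `CCCCCCCC(CCO)n1cnc2c(N(C)C)ncnc21`: > 50000 nM (a limit)
- Compound 2 `CCCCCCCC(CCO)n1cnc2c(N)ncnc21`: > 50000 nM (a limit)

Compound 1 has no numerical potency in this assay, only the limit > 50000 nM. Compound 2 also has only a limit, > 50000 nM. Together they make up the whole of the evidence so far: the limit of > 50000 nM in this assay, at which 2 of the 2 values shown sit.

Going by the values given here, the one measured step is a step that the two limits leave unreadable from compound 1 to compound 2. It concerns the group on the aromatic carbon rather than the chain, so it offers no size to carry forward.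

Compound 3 `CCCCCCCCCC(CCO)n1cnc2c(N(C)C)ncnc21` differs from compound 1 by ethyl in place of hydrogen on a saturated chain carbon, eight bonds along the chain from an aromatic nitrogen. Among the compounds with values here, no measured step tests this change, so the expectation is loose: a modest gain in this assay or none, with another limit quite possible. The expected step is an at least 1.2-fold lower number from compound 1 to compound 3 (0.09 log units; that floor lies within the scatter). Compound 3 is estimated at 40000 nM. Its expected range runs from 15000 nM to 80000 nM.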

Compound 3, half-maximal inhibitory concentration: 12200 nM
Compound 3: middle estimate off by 3.3-fold (0.52 log units), on the high side; the measured number lies below the stated range.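

In this assay, this saturated chain carbon, eight bonds along the chain from an aromatic nitrogen, is a place where a change can be read, which the earlier pair could not offer: ethyl in place of hydrogen gives an at least 4.0-fold lower number from compound 1 to compound 3 (0.61 log units; beyond the scatter). Compound 1 has only a limit, so the size of this step is a floor and not a measured gap. Compound 3 is the only compound shown with a number rather than a limit: the limit of > 50000 nM in this assay, at which 2 of the 3 values shown sit.

From the compounds shown here alone, what a still longer chain, or methyl in place of hydrogen at this carbon, would do remains open. Going by these compounds, the step from dimethylamino to amino cannot be read from the two limits, so it is also open whether amino in place of dimethylamino matters on the longer chain of compound 3.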